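From hydroxy to ethylamino on the side chain

The source may report more compounds than this note shows. Statements on the series, on what has been measured and on what is new or still open speak of the compounds shown alone.

Compound 1 `CC[C@H](N)C(=O)N[C@@H]1C(=O)N2[C@@H](CC[C@@H]1CCO)CC[C@H]2C(=O)NC(c1ccccc1)c1ccccc1`: > 100000 nM
Compound 2 `CC[C@H](NC)C(=O)N[C@@H]1C(=O)N2[C@@H](CC[C@@H]1CCNC(=O)NCc1ccccc1)CC[C@H]2C(=O)NC(c1ccccc1)c1ccccc1`: 83500 nM

Compound 1 stands at > 100000 nM in a functional assay on PC-3 cells (Homo sapiens) for cytotoxicity, read by MTT assay, with a stated time of 96 h (on this read-out higher numbers stand for weaker inhibition and lower numbers for stronger inhibition), and that entry is a limit, not a number. Compound 3 `CCNCC[C@H]1CC[C@H]2CC[C@@H](C(=O)NC(c3ccccc3)c3ccccc3)N2C(=O)[C@H]1NC(=O)[C@@H](N)CC` keeps the core of compound 1 and changes one group: ethylamino in place of hydroxy on a saturated chain carbon, two bonds along the chain from a saturated ring carbon. The new group is ethylamino in place of hydroxy on a saturated chain carbon, two bonds along the chain from a saturated ring carbon. For the measured compounds named here, no measured step shows what this change does. Going by the values given here, the only guide with a number is compound 2, which gives 83500 nM in this assay, so weak inhibition remains the likely outcome. A small move toward stronger inhibition is expected in this assay, and another result at the limit is quite possible. The expected change is an at least 1.4-fold lower number from compound 1 to compound 3 (0.15 log units; that floor lies within the scatter). For compound 3 the estimate is 70000 nM, with an expected range of 20000 nM to 100000 nM.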

Compound 3, half-maximal inhibitory concentration: > 100000 nM
Compound 3: a limit, no number; the forecaster's own chance of this, stated with the estimate: 45%; middle value at least 1.4-fold (0.15 log units) away from the limit.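

No step can be read from compound 1 to compound 3, since each stands at a limit and not at a number: the limit of > 100000 nM in this assay, at which 2 of the 3 values shown sit.

The compounds shown leave open how far, if at all, ethylamino in place of hydroxy on this chain moves inhibition.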